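The compounds below may be only part of what the source reports. "The series", "measured", "known", "first", "only" and "open" are said of these compounds alone.

Compounds measured in a functional assay on U2OS cells (Homo sapiens) for inhibition, read by CCK-8 assay, with a stated time of 72 h, tested at 1 uM; on this read-out higher numbers stand for more inhibition at the one concentration tested (going by the name of the read-out) and lower numbers for less inhibition:

Compound 1 `COc1cccc(OC)c1N1C(=O)CSC1c1cccc(C(=O)NCCCCc2ccccc2)c1` gives 41%
Compound 2 `CCN1C(=O)CSC1c1cccc(C(=O)NCCCCc2ccccc2)c1` gives 13%
Compound 3 `CC(F)(F)c1cccc(N2C(=O)CSC2c2cccc(C(=O)NCCCCc3ccccc3)c2)c1` gives 24%

Compound 1 stands highest of the three in this assay, and both steps away from it are beyond the scatter. Its nearest neighbour is compound 3, with a number 17 percentage points lower from compound 1 to compound 3 (beyond the scatter); the furthest is compound 2, with a number 28 percentage points lower from compound 1 to compound 2 (beyond the scatter). Between the two others the step is a number 11 percentage points higher from compound 2 to compound 3 (beyond the scatter). All three steps alter only the group on the amide-type nitrogen in the ring, and every departure from the 2,6-dimethoxyphenyl so far has lowered the inhibition.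

Compound 4 `COc1ccc(N2C(=O)CSC2c2cccc(C(=O)NCCCCc3ccccc3)c2)c(OC)c1` differs from compound 1 in the same place: 2,4-dimethoxyphenyl in place of 2,6-dimethoxyphenyl on an amide-type nitrogen in a ring. Within the data shown here, no measured step swaps one dimethoxyphenyl for another, so none bears on it directly. The two steps from compound 1 to compound 2 and compound 3 show that the 2,6-dimethoxyphenyl is the best of the groups tried, and a modest lowering is therefore expected when it is rearranged, smaller than the steps to an ethyl or to a fluorinated phenyl. Compound 4 is estimated at 30%, within 12% to 48%, an expected step of a number 11 percentage points lower from compound 1 to compound 4 (beyond the scatter).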

Compound 4, a percentage reported as inhibition, at one concentration (the size of the read-out at that concentration, not a potency): 37%
The estimate for compound 4 lay 7 percentage points below the measured number; the range from low to high includes it.
By their numbers in this assay, from the lowest: compound 2; then compound 3; then compounds 4 and 1 (each within the scatter of the next).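

Among these compounds, exchanging 2,6-dimethoxyphenyl for 2,4-dimethoxyphenyl on the amide-type nitrogen in the ring is the first change at this position that stays within the scatter in this assay (a number 4 percentage points lower from compound 1 to compound 4 (within the scatter)), so these two arrangements of the methoxy groups cannot be put in order. The 2,4-dimethoxyphenyl group also keeps a clear margin over the other two groups, both against the fluorinated phenyl (a number 13 percentage points higher from compound 3 to compound 4 (beyond the scatter)) and against the ethyl (a number 24 percentage points higher from compound 2 to compound 4 (beyond the scatter)). Among the four compounds, then, the higher numbers are not confined to the 2,6-dimethoxyphenyl group but are shared by both dimethoxyphenyl groups.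

The compounds shown leave open whether a phenyl with a single methoxy group, or a 3,5-dimethoxyphenyl, would stay with these two or fall towards compound 3. They also leave open what a shorter chain or a carboxylic acid would do in place of the phenylbutyl group on the amide, which is the same in all four compounds. Nothing available here explains the differences between these groups.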